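The source may report more compounds than this note shows. Statements on the series, on what has been measured and on what is new or still open speak of the compounds shown alone.

Measured in a functional assay on HeLa cells (Homo sapiens) for inhibition, read by CCK-8 assay, with a stated time of 48 h; a lower number here means a stronger inhibitor, a higher number a weaker inhibitor:
- compound 1 `O=S(=O)(NCCNC(=S)Nc1cc(C(F)(F)F)cc(C(F)(F)F)c1)c1ccc(-c2ccccc2OCc2cccc(O)c2)s1`: 14900 nM
- compound 2 `O=S(=O)(NCCNC(=S)Nc1cc(C(F)(F)F)cc(C(F)(F)F)c1)c1ccc(-c2ccccc2OCc2ccccc2)s1`: 4700 nM

With only these two numbers to compare, compound 2 is the stronger inhibitor, at 4700 nM. The next molecule is compound 3 `O=[N+]([O-])c1ccc(Oc2ccccc2-c2ccc(S(=O)(=O)NCCNC(=S)Nc3cc(C(F)(F)F)cc(C(F)(F)F)c3)s2)cc1`, which keeps the shared core of compound 2 but replaces one group: 4-nitrophenyl in place of benzyl on an oxygen on an aromatic ring. In plain terms, this puts 4-nitrophenyl in place of benzyl on an oxygen on an aromatic ring.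

Within the data shown here, only one measured step bears on this change, and only indirectly. That step is a 3.2-fold lower number from compound 1 to compound 2 (0.50 log units; beyond the scatter), with hydrogen in place of hydroxy on an aromatic carbon. It shows that a small edit within the benzyl group can move the number by a modest amount. However, no measured pair swaps the whole benzyl group, so the data do not fix a direction for compound 3. The best guess is therefore no step beyond the scatter, although a modest move either way remains possible. The expected step is a 1.3-fold higher number from compound 2 to compound 3 (0.11 log units; within the scatter). For compound 3, the estimated value in this assay is 6000 nM, with an expected range of 2000 nM to 18000 nM.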

Compound 3, half-maximal inhibitory concentration: 9900 nM
Compound 3: middle estimate off by 1.7-fold (0.22 log units), on the low side; low and high end bracket the measured number.
By their numbers in this assay, from the lowest: compound 2; then compounds 3 and 1 (each within the scatter of the next).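

Among these compounds, this is the first measured swap of the whole benzyl group on this oxygen, and in this assay 4-nitrophenyl gives a weaker inhibitor (a 2.1-fold higher number from compound 2 to compound 3 (0.32 log units; beyond the scatter)). The comparison with the 3-hydroxybenzyl compound is different (a 1.5-fold lower number from compound 1 to compound 3 (0.18 log units; within the scatter)), so compound 1 and compound 3 cannot be told apart in this assay. Among these three compounds, both departures from the plain benzyl group of compound 2 therefore raise the number, and neither of the two replacement groups improves on it. Nothing measured here explains why the number rises.

The swap changes two things at once, because benzyloxy to 4-nitrophenoxy both adds the nitro group and removes the carbon that links the ring to the oxygen, so these compounds cannot say which of the two matters. From the compounds shown here alone, a plain phenyl or a 4-nitrobenzyl group on this oxygen would separate them, and it remains open how an amine or a carboxylic acid on the same ring would behave.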